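Lengthening the alkoxy chain on the shared core

The compounds below may be only part of what the source reports. "The series", "measured", "known", "first", "only" and "open" are said of these compounds alone.

Compound 1: `CCOc1ccccc1-c1ncc(-c2nn[nH]n2)c(O)n1` gives 0.09 mg/kg in a functional assay on the whole organism with Rattus norvegicus as the target; on this read-out lower numbers stand for an effect already at smaller amounts and higher numbers for an effect only at larger amounts of compound
Compound 2: `CC(C)Oc1ccccc1-c1ncc(-c2nn[nH]n2)c(O)n1` gives 0.04 mg/kg in this assay
Compound 3: `CCCCOc1ccccc1-c1ncc(-c2nn[nH]n2)c(O)n1` not yet measured in this assay

Compound 1 stands highest of the two measured numbers; its nearest neighbour is compound 2, reached by a 2.3-fold lower number from compound 1 to compound 2 (0.35 log units; beyond the scatter). Going by the values given here, that step adds a methyl in place of hydrogen on a saturated chain carbon bound to an oxygen on an aromatic ring and a saturated chain carbon, and it is the only measured step available here.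

Compound 3 differs from compound 1 by ethyl in place of hydrogen on a saturated chain carbon, two bonds along the chain from an oxygen on an aromatic ring. Among the compounds with values here, this also enlarges the alkoxy group, so the step from compound 1 to compound 2 is the one comparison that bears on it, and it was modest. Because the measured change in the same region gave a 2.3-fold lower number from compound 1 to compound 2 (0.35 log units; beyond the scatter), a small lowering or no change beyond the scatter is the reasonable expectation; the ethyl enters two bonds further out than the methyl did, so the parallel is loose.

Compound 3 is therefore expected to give 0.06 mg/kg, within the range 0.02 mg/kg to 0.2 mg/kg, which would mean an expected 1.5-fold lower number from compound 1 to compound 3 (0.18 log units; within the scatter).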

Compound 3, dose for 50% inhibition: 0.07 mg/kg
Beside the measured number, compound 3's estimate is 1.2-fold (0.07 log units) below it; the measured number falls inside the stated range.
By their numbers in this assay, from the lowest: compounds 2, 3 and 1 (each within the scatter of the next, the first and the last beyond it).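

In this assay, the change from ethoxy to butoxy gives a 1.3-fold lower number from compound 1 to compound 3 (0.11 log units; within the scatter), so compound 1 and compound 3 cannot be told apart on this read-out, and a chain as long as butyl is accepted on the oxygen. Butyl in place of isopropyl gives a 1.8-fold higher number from compound 2 to compound 3 (0.24 log units; within the scatter), which means that compound 3 cannot be separated from compound 2 either, even though the earlier step between compound 1 and compound 2 lay beyond the scatter. Compound 3 therefore sits within the scatter of both neighbours, and these three numbers give no firm ranking of a straight chain against a branched one at this place; nothing at hand offers an explanation for the numbers.

The compounds shown leave open how far this tolerance reaches, for instance whether a hexyl chain on the oxygen, or a longer chain still, would give a number close to those of compound 1 and compound 3. They also leave open whether a more heavily branched tert-butyl group, a cyclopentyl ring or a chain ending in an amine would fit the same pattern or break from it.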